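Aryl exchange from compound 3 to compound 4

The source may hold more compounds than are shown below. What is called first, only, known or untested is meant among the compounds shown, and "the series" means these compounds.

In a toxicity assay on WI-38 cells (Homo sapiens) for inhibition, read by MTT assay, with a stated time of 48 h (a higher number here means a weaker inhibitor, a lower number a stronger inhibitor), compound 3 (`COc1ccc(/C=C2\SC(=O)N(CC(=O)Nc3c(C)n(C)n(-c4ccccc4)c3=O)C2=O)cc1`) gives 52900 nM. That value lies within the scatter of the two other measured compounds: compound 1 (`COc1ccc(/C=C2\SC(=O)N(CCNC(=O)Nc3c(C)n(C)n(-c4ccccc4)c3=O)C2=O)cc1`) gives 34500 nM and compound 2 (`COc1cc(/C=C2\SC(=O)N(CCNC(=O)Nc3c(C)n(C)n(-c4ccccc4)c3=O)C2=O)cc(OC)c1OC`) gives 51500 nM. The three numbers therefore count as a single level.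

Compound 4 (`Cc1cc(C)c(/C=C2\SC(=O)N(CC(=O)Nc3c(C)n(C)n(-c4ccccc4)c3=O)C2=O)c(C)c1`) changes one group of compound 3: 2,4,6-trimethylphenyl in place of 4-methoxyphenyl on a double-bonded chain carbon bound to a double-bonded ring carbon. The 2,4,6-trimethylphenyl group takes the place of 4-methoxyphenyl on a double-bonded chain carbon bound to a double-bonded ring carbon.

Within the data shown here, the one measured step at that place is a 1.5-fold higher number from compound 1 to compound 2 (0.17 log units; within the scatter), with 3,4,5-trimethoxyphenyl in place of 4-methoxyphenyl, and it stays within the scatter. That step was measured on the remainder of compound 1, which differs from the remainder of compound 3. Among the measured compounds shown here, no measured compound carries 2,4,6-trimethylphenyl, so the transfer is loose. No step beyond the scatter is therefore expected in this assay. The expected step is a 1.1-fold lower number from compound 3 to compound 4 (0.04 log units; within the scatter). For compound 4 the estimate is 48000 nM, with an expected range from 27000 nM to 85000 nM.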

Compound 4, half-maximal inhibitory concentration: 39100 nM
Beside the measured number, compound 4's estimate is 1.2-fold (0.09 log units) above it; the measured number falls inside the stated range.
By their numbers in this assay, from the lowest: compounds 1, 4, 2 and 3 (each within the scatter of the next).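

In this assay, among these compounds, the first aryl exchange at this place on the remainder of compound 3 gives a 1.4-fold lower number from compound 3 to compound 4 (0.13 log units; within the scatter) and stays within the scatter, as does a 1.5-fold higher number from compound 1 to compound 2 (0.17 log units; within the scatter) on the remainder of compound 1. The entering 2,4,6-trimethylphenyl group has no oxygen and no hydrogen-bond acceptor, whereas 4-methoxyphenyl has one of each, so in this pair, removing the methoxy oxygen and adding ring methyl groups does not carry the number beyond the scatter, and neither listed aryl exchange goes against that flat picture. No available evidence bears on why this exchange leaves the number at the same level.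

Still open, from the compounds shown here alone, is whether an aryl group carrying an amine or a carboxylic acid on the double-bonded chain carbon would leave this level, and whether 2,4,6-trimethylphenyl would behave alike on the remainder of compound 1. With only this assay shown, the compounds also leave open whether this exchange matters in any other assay.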